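Swapping benzylsulfanyl for propoxy on an adenine-like core

A few compounds are considered here, and "the series" means these few. Any claim that something is new, unique, unknown or untested is made for them only; others in the source may bear on it.

Measured compounds:
compound 1 `Nc1nc(SCc2ccccc2)nc2c1nc(O)n2Cc1ccccc1` — 0.1 uM
compound 2 `Nc1ncnc2c1nc(I)n2Cc1ccccc1` — > 10 uM
compound 3 `COc1ccccc1Cn1c(O)nc2c(N)ncnc21` — 10 uM

In a functional assay (spleen, spleen) for activation, with Mus musculus as the target (a higher number here means that more compound is needed for the effect, a lower number that less compound is needed), compound 1 gives 0.1 uM, the lowest of the two numbers recorded, so it is the compound needing the least material for the effect. Compound 3 `COc1ccccc1Cn1c(O)nc2c(N)ncnc21` in this assay gives 10 uM, a value far beyond the scatter from compound 1. For compound 2 `Nc1ncnc2c1nc(I)n2Cc1ccccc1` the assay reports only a limit, > 10 uM, not a number; this is the limit described by the limit of > 10 uM in this assay, at which 1 of the 3 values shown sits.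

Compound 4 `CCCOc1nc(N)c2nc(O)n(Cc3ccccc3)c2n1` has not yet been measured in this assay. It differs from compound 1 in one place: propoxy in place of benzylsulfanyl on an aromatic carbon. The group leaving and the group entering are both hydrogen-bond acceptors without donors, sitting on the same aromatic carbon between two ring nitrogen atoms of the shared core. Among the compounds with values here, no measured pair shows such a swap, so the size of the step is open. Compound 4 is expected to sit close to compound 1, with a step of about no change at the digits printed from compound 1 to compound 4 (within the scatter), not beyond the scatter. The estimate for compound 4 is 0.1 uM, within 0.02 uM to 0.5 uM.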

Compound 4, minimum effective concentration: 0.01 uM
Compound 4: the middle estimate sits 10-fold (1.00 log units) above what was measured; measured number below the stated range.
By their numbers in this assay, from the lowest: compound 4; then compound 1; then compound 3.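

At this aromatic carbon between two ring nitrogen atoms, the choice of group clearly matters: in this assay the swap gives a 10-fold lower number from compound 1 to compound 4 (1.00 log units; beyond the scatter) and so shows that less compound is needed once propoxy is in place. The six-membered aromatic ring of benzylsulfanyl is therefore not required for the effect here, and a chain with no ring, of 4 heavy atoms against 8, does better. Nothing among the data shown explains why this step goes in this direction.

The step changes sulfur to oxygen and removes the ring at once, so the compounds shown cannot say which of the two matters. Benzyloxy or propylsulfanyl at this carbon would separate them, while butoxy or a propylamino group would show how far the chain and the linking atom can vary.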